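Extending a methoxy group toward a sulfone in a shared core

The compounds below may be only part of what the source reports. "The series", "measured", "known", "first", "only" and "open" are said of these compounds alone.

Measured so far:
compound 1 `Cc1cc(OCc2cccc(-c3c(C)cc(OCCCS(C)(=O)=O)cc3C)c2)ccc1N(CC(=O)O)C(=O)c1ccccc1`, "not determined" (no result reported)
compound 2 `COc1cc(C)c(-c2cccc(COc3ccc(OCC(=O)O)c(F)c3)c2)c(C)c1`, 3.2
compound 3 `CCCCOc1cc(C)c(-c2cccc(COc3ccc(OCC(=O)O)c(F)c3)c2)c(C)c1`, "not determined" (no result reported)

Among the compounds with values here, in a physicochemical assay for lipophilicity, using the shake flask method, in phosphate buffer, measured as octanol-water partition, with a stated time of 24 h, at pH 7.4, tested at 100 uM (a higher number here means a more lipophilic compound, a lower number a more polar compound), compound 2 gives 3.2, and this is the only number available; for compound 1 and compound 3 no result was reported, so compound 2 stands alone and nothing can be said of its rank against the other two.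

Compound 4 `Cc1cc(OCCCS(C)(=O)=O)cc(C)c1-c1cccc(COc2ccc(OCC(=O)O)c(F)c2)c1` has not yet been measured. Its structure differs from compound 2 in one place: 2-(methylsulfonyl)ethyl in place of hydrogen on a saturated chain carbon bound to an oxygen on an aromatic ring. Put another way, the methoxy group of compound 2 becomes a 3-(methylsulfonyl)propoxy group in compound 4, the shared core otherwise unchanged.

Within the data shown here, since no pair of measured compounds shows a step in this assay, the direction can only be stated as an expectation. The step from compound 2 to compound 4 is expected to be a decrease of moderate size, beyond the usual scatter, about a number 0.70 log units lower from compound 2 to compound 4 (beyond the scatter). Compound 4 is therefore estimated at 2.5, with a range from 1.9 to 3.1.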

Compound 4, distribution coefficient: 1.81
Beside the measured number, compound 4's estimate is 0.69 log units above it; measured number outside the range, below it.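

In this assay, the change of methoxy to 3-(methylsulfonyl)propoxy on the shared core brings a number 1.39 log units lower from compound 2 to compound 4 (beyond the scatter), a large step and the first that can be read at this position. It shows that the read-out responds strongly to what is placed on this saturated chain carbon bound to an oxygen on an aromatic ring, even though the entering 2-(methylsulfonyl)ethyl carries no net charge. Nothing at hand bears on why the step has this size.

Compound 3, with a butoxy group in the same place, gives "not determined" (no result reported), so the shown compounds do not separate the share of the longer chain from that of the sulfone. As far as these compounds go, how a 3-hydroxypropoxy group or a chain ending in an amine would compare at this position also remains open.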